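Replacing the dimethylamino of compound 1 with a hydroxy

The compounds below may be only part of what the source reports. "The series", "measured", "known", "first", "only" and "open" are said of these compounds alone.

Measured so far in a physicochemical assay for solubility, read by nephelometry, in phosphate buffer, at pH 7.4; a lower number here means a less soluble compound, a higher number a more soluble compound:
compound 1 `Cc1cc2ccccc2n1CCNC(=O)/C=C/c1ccc(OCCCN(C)C)cc1`: 306000 nM
compound 3 `COc1cc(/C=C/C(=O)NCCn2c(C)c(CN3CCCCC3)c3ccccc32)cc(OC)c1OC`: 75000 nM
compound 2 `Cc1cc(/C=C/C(=O)NCCn2c(C)cc3ccccc32)cc(C)c1F`: < 25000 nM

Compound 1 has the highest of the two numbers shown; the nearest is compound 3, whose value lies beyond the scatter below it. Compound 2 gives only a limit of the assay, (the limit of < 25000 nM in this assay, at which 1 of the 3 values shown sits), and no number.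

Compound 4 `Cc1cc2ccccc2n1CCNC(=O)/C=C/c1ccc(OCCCO)cc1` differs from compound 1 in one place: hydroxy in place of dimethylamino on a saturated chain carbon, three bonds along the chain from an oxygen on an aromatic ring. Going by the values given here, no measured pair shows this kind of change, so its size is uncertain. In this assay compound 4 is expected to come out lower than compound 1, by a 3.8-fold lower number from compound 1 to compound 4 (0.58 log units; beyond the scatter). The estimate for compound 4 is 80000 nM, between 20000 nM and 250000 nM.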

Compound 4, solubility: 66000 nM
The estimate for compound 4 lay 1.2-fold (0.08 log units) above the measured number; measured number inside the range.
By their numbers in this assay, from the lowest: compounds 4 and 3 (each within the scatter of the next); then compound 1. At a limit, below all of these: compound 2.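

In this assay, the end of the 3-(dimethylamino)propyl chain turns out to count: hydroxy in place of dimethylamino gives a 4.6-fold lower number from compound 1 to compound 4 (0.67 log units; beyond the scatter), the first single-place step read at this position. The core and the rest of the chain stay the same, so this step isolates that one exchange. Nothing shown bears on what lies behind the step.

As far as these compounds go, whether another amine, such as a morpholine, or a carboxylic acid at this chain end would match compound 1 remains open. So does the effect of a shorter or longer chain carrying the dimethylamino.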